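The source may hold more compounds than are shown below. What is called first, only, known or untested is meant among the compounds shown, and "the series" means these compounds.

In a functional assay on BaF3 cells (Mus musculus) for antiproliferative activity, read by CCK-8 assay and cell counting, with a stated time of 76 h (a lower number here means a stronger inhibitor, a higher number a weaker inhibitor), compound 2 `COc1cc2nccc(Oc3ccc(Nc4nn(C)cc4C(=O)N4CCCC5CCCCC54)cc3)c2cc1C(N)=O` gives 4330 nM. Compound 1 `COc1cc2nccc(Oc3ccc(Nc4nn(C)cc4C(=O)N4CCCCC4)cc3)c2cc1C(N)=O` gives 5650 nM in this assay. Among the measured compounds shown here, the one measured step, a 1.3-fold lower number from compound 1 to compound 2 (0.12 log units; within the scatter), lies within the scatter, so compound 2 stands at no distance from compound 1 beyond the scatter. Compound 3 `COc1cc2nccc(Oc3ccc(Nc4nn(C)cc4C(=O)NCc4ccccc4)cc3)c2cc1C(N)=O` has not been measured; it differs from compound 2 by a group of 8 heavy atoms (7 carbon, 1 nitrogen; one six-membered aromatic ring of carbon only) in place of a group of 10 heavy atoms (9 carbon, 1 nitrogen; one six-membered non-aromatic ring of carbon only, one six-membered non-aromatic ring with 1 hetero atom), on a carbonyl carbon. For the measured compounds named here, that earlier step, which exchanged groups on the same carbonyl carbon, gave no change beyond the scatter, and no measured step speaks to a benzylamino group. No step beyond the scatter is therefore expected in this assay. Compound 3 is estimated at 4500 nM, within 1500 nM to 13500 nM. The expected step is a 1.0-fold higher number from compound 2 to compound 3 (0.02 log units; within the scatter).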

Compound 3, half-maximal inhibitory concentration: > 10000 nM
Compound 3: no number, only a limit (the forecaster's own chance of this, stated with the estimate: 5%); at least 2.2-fold (0.34 log units) between middle value and limit.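

Benzylamino on this carbonyl carbon gives what the earlier exchange of groups there did not, a step beyond the scatter in this assay: an at least 2.3-fold higher number from compound 2 to compound 3 (0.36 log units; beyond the scatter). Against piperidin-1-yl the reading is weaker, an at least 1.7-fold higher number from compound 1 to compound 3 (0.24 log units; that floor lies within the scatter), so that comparison alone settles nothing. The result for compound 3 is a limit, not a number: the limit of > 10000 nM in this assay, at which 1 of the 3 values shown sits.

From the compounds shown here alone, how far compound 3 lies past that limit stays open. Also open, going by these compounds, is whether the amide hydrogen or the aromatic ring goes with this step, which a cyclohexylmethylamino group on the same carbonyl carbon could help separate.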